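The source may hold more compounds than are shown below. What is called first, only, known or untested is meant among the compounds shown, and "the series" means these compounds.

Going by the values given here, in a functional assay on PC-3 cells (Homo sapiens) for antiproliferative activity, read by MTT assay, with a stated time of 48 h (on this read-out lower numbers stand for stronger inhibition and higher numbers for weaker inhibition), compound 3 `Oc1ccc(N2CCN(CC(O)COc3ccc(O)c4ccccc34)CC2)c(O)c1` gives 17700 nM and has the lowest number of the three measured so far; compound 2 `Oc1ccccc1N1CCN(CC(O)COc2ccc(O)c3ccccc23)CC1` gives 26100 nM and compound 1 `COc1cc(O)ccc1N1CCN(CC(O)COc2ccc(O)c3ccccc23)CC1` gives 45700 nM. Compound 4 `COc1ccccc1N1CCN(CC(O)COc2ccc(O)c3ccccc23)CC1` differs from compound 3 by 2-methoxyphenyl in place of 2,4-dihydroxyphenyl on an amine nitrogen in a ring. Among the compounds with values here, two measured steps bear on this: a 1.5-fold lower number from compound 2 to compound 3 (0.17 log units; within the scatter), so the hydroxy that leaves is not expected to matter much, while a 2.6-fold lower number from compound 1 to compound 3 (0.41 log units; beyond the scatter), which runs in the opposite direction to the methyl that now enters. On balance, a modest rise in this assay is expected for compound 4, about a 2.0-fold higher number from compound 3 to compound 4 (0.30 log units; within the scatter), so that compound 4 is estimated at 35000 nM with a range of 15000 nM to 80000 nM.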

Compound 4, half-maximal inhibitory concentration: 28000 nM
For compound 4 the middle estimate is 1.3-fold (0.10 log units) above the measured one; measured number inside the range.
By their numbers in this assay, from the lowest: compounds 3, 2, 4 and 1 (each within the scatter of the next, the first and the last beyond it).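

In this assay the full exchange of 2,4-dihydroxyphenyl for 2-methoxyphenyl on the amine nitrogen stays small (a 1.6-fold higher number from compound 3 to compound 4 (0.20 log units; within the scatter)), and so do its single edits: methyl on the oxygen (a 1.1-fold higher number from compound 2 to compound 4 (0.03 log units; within the scatter)) and hydrogen in place of hydroxy (a 1.6-fold lower number from compound 1 to compound 4 (0.21 log units; within the scatter)). Going by these compounds alone, the one step beyond the scatter, removal of the methyl from the core of compound 1, has no clear counterpart on the second core, yet the two readings cannot be separated: the same change on two cores in this assay, a 2.6-fold lower number (0.41 log units; beyond the scatter) from compound 1 to compound 3 and a 1.1-fold lower number (0.03 log units; within the scatter) from compound 4 to compound 2, 2.4-fold (0.38 log units) apart, within the scatter of two such steps. The added hydroxy likewise gives no separable difference between cores: the same change on two cores in this assay, a 1.5-fold lower number (0.17 log units; within the scatter) from compound 2 to compound 3 and a 1.6-fold higher number (0.21 log units; within the scatter) from compound 4 to compound 1, 2.4-fold (0.38 log units) apart, within the scatter of two such steps. Open, as far as these compounds go, is whether a group of another kind on this aromatic ring, such as an amine or a carboxylic acid, moves the number beyond the scatter.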